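Swapping the pyrazole for an ester-bearing thiazole

A few compounds are considered here, and "the series" means these few. Any claim that something is new, unique, unknown or untested is made for them only; others in the source may bear on it.

Measured compounds:
Compound 1 `CC1(C)CC(NC(=O)c2ccc(Nc3ncc([N+](=O)[O-])c(NC4CCCC4)n3)cc2)CC(C)(C)N1[O]`: 33200 nM
Compound 2 `Cc1cc(Nc2nc(Nc3ccc(C(=O)NC4CC(C)(C)N([O])C(C)(C)C4)cc3)ncc2[N+](=O)[O-])no1`: 1140 nM
Compound 3 `Cc1cc(Nc2nc(Nc3ccc(C(=O)NC4CC(C)(C)N([O])C(C)(C)C4)cc3)ncc2[N+](=O)[O-])n[nH]1`: 15300 nM

All three share one core and differ only in the group on a nitrogen on an aromatic ring. In a functional assay on A549 cells (Homo sapiens) for antiproliferative activity, read by MTT assay, with a stated time of 48 h (on this read-out higher numbers stand for weaker inhibition and lower numbers for stronger inhibition), compound 3 stands second highest of the three numbers; it sits nearest to compound 1, shown by a 2.2-fold lower number from compound 1 to compound 3 (0.34 log units; beyond the scatter), and furthest from compound 2, shown by a 13-fold higher number from compound 2 to compound 3 (1.13 log units; beyond the scatter). The strongest result came with a 29-fold lower number from compound 1 to compound 2 (1.46 log units; beyond the scatter).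

Compound 4 `CCOC(=O)c1csc(Nc2nc(Nc3ccc(C(=O)NC4CC(C)(C)N([O])C(C)(C)C4)cc3)ncc2[N+](=O)[O-])n1` is the next step from compound 3: 4-(ethoxycarbonyl)-1,3-thiazol-2-yl in place of 5-methyl-1H-pyrazol-3-yl on a nitrogen on an aromatic ring. The bearing steps are those replacing the cyclopentyl or pyrazolyl by another five-membered aromatic ring, which gave a 29-fold lower number from compound 1 to compound 2 (1.46 log units; beyond the scatter) and a 13-fold higher number from compound 2 to compound 3 (1.13 log units; beyond the scatter). Going by these compounds, an aromatic ring without the ring donor resembles compound 2 more than compound 3, so a sizeable move to a lower number in this assay is expected, though the ester and sulfur are untested here. Compound 4 is therefore estimated at 3000 nM (range 600 nM to 15000 nM), meaning an expected step of a 5.1-fold lower number from compound 3 to compound 4 (0.71 log units; beyond the scatter).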

Compound 4, half-maximal inhibitory concentration: 740 nM
Compound 4: the middle estimate sits 4.1-fold (0.61 log units) above what was measured; the measured number falls inside the stated range.
By their numbers in this assay, from the lowest: compounds 4 and 2 (each within the scatter of the next); then compound 3; then compound 1.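

In this assay, the result shows that this position, on a nitrogen on an aromatic ring, can carry the larger 4-(ethoxycarbonyl)-1,3-thiazol-2-yl group with no loss against either earlier five-membered ring, as seen in two large steps (a 21-fold lower number from compound 3 to compound 4 (1.32 log units; beyond the scatter); a 45-fold lower number from compound 1 to compound 4 (1.65 log units; beyond the scatter)). The step from the 5-methyl-1,2-oxazol-3-yl group lies within the scatter (a 1.5-fold lower number from compound 2 to compound 4 (0.19 log units; within the scatter)), so two different rings now read alike, and 5-methyl-1H-pyrazol-3-yl stands apart from both. Nothing measured here accounts for these differences.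

Going by these compounds, the thiazole appears only with its ester, so the share of the ethoxycarbonyl group in this result remains unknown. On these data alone, how a carboxylic acid, a primary amide or a bare hydrogen would read in its place stays open, as does a pyridin-2-yl group in place of the thiazole.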